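The source may hold more compounds than are shown below. What is called first, only, known or untested is meant among the compounds shown, and "the series" means these compounds.

Measured compounds in an ADME assay on WI-38 cells (Homo sapiens) for inhibition, read by MTT assay, with a stated time of 72 h; a higher number here means a weaker inhibitor, a lower number a stronger inhibitor:

compound 1, `O=C(OC1(C(=O)Nc2ccc([N+](=O)[O-])cc2)CCCCC1)c1ccc(Cl)cc1`: 355 nM
compound 2, `Cc1ccccc1C(=O)OC1(C(=O)Nc2ccc([N+](=O)[O-])cc2)CCCCC1`: 352 nM
compound 3, `O=COC1(C(=O)Nc2ccc([N+](=O)[O-])cc2)CCCCC1`: 46.3 nM

Compound 1 gives the highest of the three numbers in this assay. Its nearest neighbour is compound 2, a 1.0-fold lower number from compound 1 to compound 2 (0.00 log units; within the scatter), so the two aryl esters cannot be told apart. The formate, compound 3, stands furthest away, a 7.7-fold lower number from compound 1 to compound 3 (0.88 log units; beyond the scatter), and the matching step from the other aryl ester runs the same way, a 7.6-fold lower number from compound 2 to compound 3 (0.88 log units; beyond the scatter).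

The next compound, compound 4, `CCC(=O)OC1(C(=O)Nc2ccc([N+](=O)[O-])cc2)CCCCC1`, is not yet measured. Relative to compound 1 the change is ethyl in place of 4-chlorophenyl on a carbonyl carbon.

Of the measured steps, the exchange of one aryl group for another left the number unchanged. Hydrogen in place of the aryl group gave a modestly lower number, a 7.7-fold lower number from compound 1 to compound 3 (0.88 log units; beyond the scatter). Ethyl sits somewhere between those two cases, so a lower number than compound 1 is expected, but not a step as large as the one to compound 3. For compound 4 the estimated step is a 2.7-fold lower number from compound 1 to compound 4 (0.44 log units; beyond the scatter). Compound 4 is therefore expected to give 130 nM in this assay, with a range from 55 nM to 320 nM.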

Compound 4, half-maximal inhibitory concentration: 44.6 nM
For compound 4 the middle estimate is 2.9-fold (0.46 log units) above the measured one; measured number outside the range, below it.
By their numbers in this assay, from the lowest: compounds 4 and 3 (each within the scatter of the next); then compounds 2 and 1 (each within the scatter of the next).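

At this place, on a carbonyl carbon whose other neighbour is oxygen, ethyl groups with hydrogen and not with the aryl groups in this assay (a 1.0-fold lower number from compound 3 to compound 4 (0.02 log units; within the scatter)). The steps from the two aryl esters are of one size (an 8.0-fold lower number from compound 1 to compound 4 (0.90 log units; beyond the scatter); a 7.9-fold lower number from compound 2 to compound 4 (0.90 log units; beyond the scatter)), so among these four compounds the whole gap lies between the aryl esters, compounds 1 and 2, and the non-aryl pair, compounds 3 and 4. Nothing at hand accounts for this division.

Compounds 1 and 2 carry both a six-membered aromatic ring and more heavy atoms than ethyl, so the ring and the size of the group cannot be told apart here. On these data alone, how a longer chain such as hexyl or a saturated ring such as cyclohexyl would read in this assay stays open.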